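The compounds below may be only part of what the source reports. "The series", "measured", "known", "first", "only" and "open" are said of these compounds alone.

Compound 1 `Cc1cc(Nc2cc(N3CCN(C)CC3)nc(Nc3cccc([N+](=O)[O-])c3)n2)n[nH]1` stands lowest of the three numbers measured in a functional assay on NCI-N87 cells (Homo sapiens) for antiproliferative activity, read by CCK-8 assay, with a stated time of 72 h; on this read-out higher numbers stand for weaker inhibition and lower numbers for stronger inhibition: compound 1 gives 4320 nM, whereas compound 2 `Cc1cc(Nc2cc(N3CCN(C)CC3)nc(Nc3ccc(S(N)(=O)=O)cc3)n2)n[nH]1` gives 24000 nM and compound 3 `COc1ccc(Nc2nc(Nc3cc(C)[nH]n3)cc(N3CCN(C)CC3)n2)cc1` gives 18900 nM. Compound 4 `COc1cccc(Nc2nc(Nc3cc(C)[nH]n3)cc(N3CCN(C)CC3)n2)c1` differs from compound 1 by methoxy in place of nitro on an aromatic carbon. Among the measured compounds shown here, two measured steps bear on this exchange of the 3-nitrophenyl: a 5.6-fold higher number from compound 1 to compound 2 (0.74 log units; beyond the scatter) and a 4.4-fold higher number from compound 1 to compound 3 (0.64 log units; beyond the scatter), each a modest rise, while a 1.3-fold lower number from compound 2 to compound 3 (0.10 log units; within the scatter), so the two replacements came out alike. Given a 4.4-fold higher number from compound 1 to compound 3 (0.64 log units; beyond the scatter) as the closest precedent, compound 4 is expected to show a 2.8-fold higher number from compound 1 to compound 4 (0.44 log units; beyond the scatter), a modest rise rather than none. The estimate for compound 4 in this assay is 12000 nM, with a range from 5000 nM to 30000 nM.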

Compound 4, half-maximal inhibitory concentration: 7190 nM
Estimate against measurement, compound 4: 1.7-fold (0.22 log units) above; measured number inside the range.
By their numbers in this assay, from the lowest: compounds 1 and 4 (each within the scatter of the next); then compounds 3 and 2 (each within the scatter of the next).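

In this assay the nitro group proves dispensable at this position, as methoxy in its place gives a 1.7-fold higher number from compound 1 to compound 4 (0.22 log units; within the scatter). The place of the substituent counts for more than the exchange itself, with moving methoxy to the 3-position of the phenyl giving a 2.6-fold lower number from compound 3 to compound 4 (0.42 log units; beyond the scatter), and the 3-methoxyphenyl also comparing with the 4-sulfamoylphenyl by a 3.3-fold lower number from compound 2 to compound 4 (0.52 log units; beyond the scatter). Nothing measured here explains these steps. Going by these compounds, whether an amine or a carboxylic acid on the same aromatic carbon would keep the number as low remains open.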